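The compounds below may be only part of what the source reports. "The series", "measured", "known", "first", "only" and "open" are said of these compounds alone.

Measured so far in a functional assay on KB cells (Homo sapiens) for cytotoxicity, read by sulforhodamine B assay; on this read-out lower numbers stand for an effect already at smaller amounts and higher numbers for an effect only at larger amounts of compound:
- compound 1 `C=C1CC[C@@H]2[C@](C)(CO[Si](C(C)C)(C(C)C)C(C)C)[C@H](OC(C)=O)CC[C@@]2(C)[C@@H]1C/C=C1/C(=O)OC[C@H]1OC(C)=O` gives 7.39 uM
- compound 2 `C=C1CC[C@@H]2[C@](C)(CO)[C@H](OC(C)=O)CC[C@@]2(C)[C@@H]1C/C=C1/C(=O)OC[C@H]1O` gives 35.7 uM

Compound 2 stands at the highest of the two numbers in this assay; the nearest is compound 1, whose number is lower by a margin beyond the usual scatter. Among the measured compounds shown here, compound 1 differs from compound 2 in more than one place, so no single step is worked out for that pair; the two values show only that compound 2 needs the larger amount of compound for the half-maximal effect.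

Compound 3 `C=C1CC[C@@H]2[C@](C)(CO)[C@H](OC(C)=O)CC[C@@]2(C)[C@@H]1C/C=C1/C(=O)OC[C@H]1OC(C)=O` is the next compound in the series and has not yet been measured. It differs from compound 2 in one place: acetyl in place of hydrogen on an oxygen on a saturated carbon. For the measured compounds named here, since no step between measured compounds is available, the expectation for compound 3 rests on the two values alone. The step of a 2.0-fold lower number from compound 2 to compound 3 (0.30 log units; within the scatter) is expected to run downward, toward the number of compound 1, but not to reach it, because compound 1 carries a second change in addition to this one and gives 7.39 uM. A modest step, at the edge of the scatter or somewhat beyond it, is the working expectation. For compound 3 the estimate in this assay is 18 uM, with a range from 6 uM to 45 uM.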

Compound 3, concentration for half-maximal effect: 11.7 uM
Compound 3: the middle estimate sits 1.5-fold (0.19 log units) above what was measured; the range from low to high includes it.
By their numbers in this assay, from the lowest: compounds 1 and 3 (each within the scatter of the next); then compound 2.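

In this assay, the change from hydroxy to acetoxy on an oxygen on a saturated carbon now has a measured size: a 3.1-fold lower number from compound 2 to compound 3 (0.48 log units; beyond the scatter). This shows that acetyl in place of hydrogen at this place lowers the number by more than the scatter, which the two earlier values could not separate from the second difference carried by compound 1. With the acetoxy in place, the silicon-bearing group of compound 1 has no readable effect on the number, as a 1.6-fold higher number from compound 1 to compound 3 (0.20 log units; within the scatter) shows, and no measurement given here bears on the cause of either step.

On these data alone, whether the lower number is specific to acetyl stays open, since a longer acyl chain such as butanoyl, a benzoyl ester or a methyl ether on the same oxygen could give a different step. As far as these compounds go, it is also open whether the silicon-bearing group would leave the number unchanged on the core of compound 2, where hydroxy takes the place of acetoxy, or whether an amine or a carboxylic acid would be tolerated at either oxygen-bearing place.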